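Pyridin-4-yl for pyridin-3-yl across two cores

The compounds below may be only part of what the source reports. "The series", "measured", "known", "first", "only" and "open" are said of these compounds alone.

Compound 1 `O=C(/C=C/c1cn(-c2ccccc2)nc1-c1cccnc1)c1ccccc1` and compound 3 `O=C(/C=C/c1cn(-c2ccccc2)nc1-c1ccncc1)c1ccccc1` share one core and differ by pyridin-4-yl in place of pyridin-3-yl on an aromatic carbon. In a functional assay on Huh-7 cells (Homo sapiens) for inhibition, read by sulforhodamine B assay, with a stated time of 72 h (a lower number here means a stronger inhibitor, a higher number a weaker inhibitor), compound 1 gives 2300 nM, while compound 3 gives 1800 nM; the step is a 1.3-fold lower number from compound 1 to compound 3 (0.11 log units; within the scatter). Compound 2 `COc1ccc(C(=O)/C=C/c2cn(-c3ccccc3)nc2-c2cccnc2)c(OC)c1OC` rests on a second core, and the difference between the two cores is not broken down here. In this assay compound 2 gives 2300 nM, level with compound 1 and within the scatter of compound 3. Compound 4 `COc1ccc(C(=O)/C=C/c2cn(-c3ccccc3)nc2-c2ccncc2)c(OC)c1OC` is not yet measured; it stands to compound 2 as compound 3 stands to compound 1, by pyridin-4-yl in place of pyridin-3-yl on an aromatic carbon, the same change at the same place. In this assay the expected step is a 1.2-fold lower number from compound 2 to compound 4 (0.06 log units; within the scatter), set beside a 1.3-fold lower number from compound 1 to compound 3 (0.11 log units; within the scatter), because a 1.3-fold lower number from compound 1 to compound 3 (0.11 log units; within the scatter) lay within the scatter and nothing else on the second core is known. Compound 4 is therefore estimated at 2000 nM, from 1000 nM to 4000 nM.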

Compound 4, half-maximal inhibitory concentration: 3700 nM
For compound 4 the middle estimate is 1.9-fold (0.27 log units) below the measured one; the measured number falls inside the stated range.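

In this assay the same change gives a 1.3-fold lower number from compound 1 to compound 3 (0.11 log units; within the scatter) on one core and a 1.6-fold higher number from compound 2 to compound 4 (0.21 log units; within the scatter) on the other, and both steps lie within the scatter. Neither the steps nor the gap between them can be read as a real difference, so these two pairs give no sign that the outcome depends on the core: the same change on two cores in this assay, a 1.3-fold lower number (0.11 log units; within the scatter) from compound 1 to compound 3 and a 1.6-fold higher number (0.21 log units; within the scatter) from compound 2 to compound 4, 2.1-fold (0.31 log units) apart, within the scatter of two such steps. This does not show that the change is neutral or that it behaves identically on both cores, and two pairs set no rule for the wider series.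

Still open, as far as these compounds go, is whether a pyridin-2-yl or plain phenyl group at this place would give a step beyond the scatter. Also open, from the compounds shown here alone, is whether the change would carry over to a core bearing an amine or a carboxylic acid.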